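Working notes: adding methyl to compound 3

The source may hold more compounds than are shown below. What is called first, only, known or untested is meant among the compounds shown, and "the series" means these compounds.

Among the measured compounds shown here, in an ADME assay on HEL cells (Homo sapiens) for cytotoxicity (a lower number here means that less compound is tolerated, a higher number that more compound is tolerated), compound 3 `O=C(COc1cccc2ccccc12)N/N=C/c1ccccc1` gives 64.5 ug/mL and lies within the scatter of compound 2 `O=C(COc1cccc2ccccc12)N/N=C/c1cccc([N+](=O)[O-])c1` at 61.2 ug/mL and of compound 1 `O=C(COc1cccc2ccccc12)N/N=C/c1ccccc1Br` at 100 ug/mL on the numbers so far. Compound 4 `Cc1ccc(/C=N/NC(=O)COc2cccc3ccccc23)cc1` has methyl in place of hydrogen on an aromatic carbon, para to a large group (methyl in place of hydrogen on an aromatic carbon). The nearest evidence is two swaps to hydrogen on an aromatic carbon: losing bromo gives a 1.6-fold lower number from compound 1 to compound 3 (0.19 log units; within the scatter) and losing nitro gives a 1.1-fold higher number from compound 2 to compound 3 (0.02 log units; within the scatter) and both stay within the scatter. For the measured compounds named here, no methyl compound has been measured, so no step beyond the scatter is expected in this assay for this change. An estimated 1.1-fold higher number from compound 3 to compound 4 (0.02 log units; within the scatter) is all that is expected. For compound 4 the estimate is 68 ug/mL within an expected range of 38 ug/mL to 110 ug/mL in this series.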

Compound 4, half-maximal cytotoxic concentration: 80.1 ug/mL
The estimate for compound 4 lay 1.2-fold (0.07 log units) below the measured number; low and high end bracket the measured number.
By their numbers in this assay, from the lowest: compounds 2, 3, 4 and 1 (each within the scatter of the next).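

Methyl on this ring, para to a large group, gives a 1.2-fold higher number from compound 3 to compound 4 (0.09 log units; within the scatter) in this assay and so adds a first direct reading for this position, with no step beyond the scatter. The swap of 2-bromophenyl for 4-methylphenyl gives a 1.2-fold lower number from compound 1 to compound 4 (0.10 log units; within the scatter) and also stays within the scatter, so these two substituted rings are not separated here. Nothing measured on hand offers an explanation for these small steps. Still open, going by these compounds, is whether an amine, a carboxylic acid or a longer chain at this position would give a step beyond the scatter.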